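This account rests on a few compounds, and the source may have more. Where it says the series, first, only, none or still open, it means among the compounds named here.

Measured so far:
compound 1 `CCCC(C)n1c(CC)nc2c(-c3ccc(OC)cc3C)ccnc21` — 0.8 nM
compound 2 `CCc1nc2c(-c3ccc(Cl)cc3Cl)ccnc2n1C(CCOC)C1CC1` — 1.5 nM
compound 3 `CCCC(C)n1c(CC)nc2c(-c3ccc(S(C)(=O)=O)cc3C(F)(F)F)ccnc21` — 6.8 nM

All three numbers come from an assay for binding affinity to Corticotropin releasing factor receptor (Rattus norvegicus); on this read-out higher numbers stand for weaker inhibition and lower numbers for stronger inhibition. Compound 2 stands second highest of the three. Its nearest neighbour is compound 1, with a lower number that still lies within the scatter; compound 3 is furthest, with a higher number that lies beyond the scatter. Compound 2 and compound 1 therefore cannot be told apart on this read-out, while compound 3 sits clearly above both.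

Compound 4 `CCc1nc2c(-c3ccc(Cl)cc3Cl)ccnc2n1[C@@H](CC)C1CC1` has not been measured. It differs from compound 2 in one place: 1-cyclopropylpropyl in place of 1-cyclopropyl-3-methoxypropyl on an aromatic nitrogen. The 1-cyclopropyl-3-methoxypropyl group gives way to 1-cyclopropylpropyl; the three-membered non-aromatic ring of carbon only remains in both.

Going by the values given here, no step between measured compounds touches this position, so the expectation rests on the spread of the series alone. Among the compounds with values here, compound 1 gives 0.8 nM, within the scatter of compound 2, and compound 3 is the only number beyond it. The expected step of no change at the digits printed from compound 2 to compound 4 (within the scatter) is small, none beyond the scatter, in either direction. For compound 4 the estimate is 1.5 nM, with a range from 0.5 nM to 4.5 nM.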

Compound 4, inhibition constant: 0.4 nM
Estimate against measurement, compound 4: 3.8-fold (0.57 log units) above, outside the stated range (below it).
By their numbers in this assay, from the lowest: compounds 4, 1 and 2 (each within the scatter of the next, the first and the last beyond it); then compound 3.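

In this assay, the substituent on the aromatic nitrogen now has its first readable step: 1-cyclopropylpropyl in place of 1-cyclopropyl-3-methoxypropyl gives a 3.8-fold lower number from compound 2 to compound 4 (0.57 log units; beyond the scatter), so the number responds to a change at this position. The change removes the only hydrogen-bond acceptor of the group and goes from 8 to 6 heavy atoms while the three-membered ring stays, and in this pair a low number does not depend on the methoxy end of the chain. Nothing measured here accounts for the step, and this one pair cannot separate the loss of the oxygen from the shorter chain or from the defined stereocentre in compound 4.

Open, on these data alone, is how the number would respond to a hydroxyl group or an amine at the end of the chain, or to a longer all-carbon chain such as 1-cyclopropylbutyl. Also open, as far as these compounds go, are the opposite configuration of the 1-cyclopropylpropyl group and whether the same step would hold with the aryl groups of compound 1 or compound 3 on the shared core.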